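The compounds below may be only part of what the source reports. "The series", "measured", "known", "first", "only" and "open" are said of these compounds alone.

Working notes on the series. In a functional assay on SK-OV-3 cells (Homo sapiens) for cytotoxicity, read by MTT assay, with a stated time of 3 days (a lower number here means a stronger inhibitor, a higher number a weaker inhibitor), compound 1 `N#Cc1c(O)nc(SCc2nc3ccccc3[nH]2)nc1-c1ccccc1` gives 2.55 nM, compound 2 `N#Cc1c(Cl)nc(SCc2nc3ccccc3[nH]2)nc1-c1ccccc1` gives 3.37 nM and compound 3 `N#Cc1c(NC(N)=O)nc(SCc2nc3ccccc3[nH]2)nc1-c1ccccc1` gives 6.75 nM. The three differ only in the group on one aromatic carbon of the shared core. Compound 3 is separated from compound 1 by a 2.6-fold higher number from compound 1 to compound 3 (0.42 log units; beyond the scatter), a modest step and the only one of the three beyond the scatter. Its step from compound 2 is smaller: a 2.0-fold higher number from compound 2 to compound 3 (0.30 log units; within the scatter). The remaining step is a 1.3-fold higher number from compound 1 to compound 2 (0.12 log units; within the scatter).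

Compound 4 `CN1CCN(c2nc(SCc3nc4ccccc4[nH]3)nc(-c3ccccc3)c2C#N)CC1` changes the same carbon: 4-methylpiperazin-1-yl in place of ureido on an aromatic carbon. In words, 4-methylpiperazin-1-yl stands in place of ureido. Within the data shown here, these three steps are the only evidence for this carbon, and they show hydroxy, chloro and ureido exchanged with little movement in this assay. Among the measured compounds shown here, none of the measured compounds carries a ring at this carbon, so the data do not test this kind of replacement, and the range has to stay wide. With a 2.6-fold higher number from compound 1 to compound 3 (0.42 log units; beyond the scatter) as the largest measured step, no clear direction is expected, and no shift well beyond the scatter. The expected change is a 1.4-fold lower number from compound 3 to compound 4 (0.13 log units; within the scatter). For compound 4 the estimated value is 5 nM, with an expected range from 1.5 nM to 18 nM.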

Compound 4, half-maximal inhibitory concentration: 1600 nM
For compound 4 the middle estimate is 320-fold (2.51 log units) below the measured one; the whole stated range lies below it.
By their numbers in this assay, from the lowest: compounds 1, 2 and 3 (each within the scatter of the next, the first and the last beyond it); then compound 4.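

In this assay this carbon proves far less tolerant than the exchange of hydroxy, chloro and ureido suggested: placing 4-methylpiperazin-1-yl here gives a 240-fold higher number from compound 3 to compound 4 (2.37 log units; beyond the scatter) and, measured against the other two groups, a 470-fold higher number from compound 2 to compound 4 (2.68 log units; beyond the scatter) and also a 630-fold higher number from compound 1 to compound 4 (2.80 log units; beyond the scatter) on the same scale. Compound 4 is the only one of the series with a ring at this carbon, and its group of 7 heavy atoms is the largest here, so the position clearly separates this replacement from the three smaller groups, whose own steps are far smaller. Nothing available bears on why the number rises so steeply with this replacement.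

The compounds shown leave open whether the rise goes with the six-membered non-aromatic ring itself, with the size of the group, or with the methyl on the piperazine. A dimethylamino group, which is an open chain without a ring, or a plain amino group on this carbon would begin to separate these readings, and a piperazine without the methyl would test the last of them.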